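Chloro for cyano on the aryl of compound 2

The source may hold more compounds than are shown below. What is called first, only, known or untested is meant among the compounds shown, and "the series" means these compounds.

The measured members of the series are compound 1 `CC1(C)[C@H]2CC[C@]1(C)N(Cc1cn(-c3cccc(F)c3)nn1)C(=O)C2`, compound 2 `CC1(C)[C@H]2CC[C@]1(C)N(Cc1cn(-c3ccc(C#N)cc3)nn1)C(=O)C2` and compound 3 `CC1(C)[C@H]2CC[C@]1(C)N(Cc1cn(-c3ccc(F)cc3)nn1)C(=O)C2`, all on the shared core. In a functional assay on PANC-1 cells (Homo sapiens) for inhibition, read by MTT assay, with a stated time of 24 h (on this read-out higher numbers stand for weaker inhibition and lower numbers for stronger inhibition), compound 1 gives 220 nM, compound 2 gives 250 nM and compound 3 gives 110 nM. Compound 2 holds the highest of the three numbers: the step of a 1.1-fold higher number from compound 1 to compound 2 (0.06 log units; within the scatter) is within the scatter, whereas the step of a 2.3-fold lower number from compound 2 to compound 3 (0.36 log units; beyond the scatter) is beyond it, so compound 2 and compound 1 cannot be ordered against each other, but compound 2 does sit above compound 3.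

Compound 4 `CC1(C)[C@H]2CC[C@]1(C)N(Cc1cn(-c3ccc(Cl)cc3)nn1)C(=O)C2` is not yet measured. It differs from compound 2 by chloro in place of cyano on an aromatic carbon. The measured step that bears on it is a 2.3-fold lower number from compound 2 to compound 3 (0.36 log units; beyond the scatter), in which a halogen took the place of the cyano on the same aromatic carbon and gave a modest lowering. The step of a 2.0-fold lower number from compound 1 to compound 3 (0.30 log units; within the scatter) concerns only where the fluoro sits and is within the scatter, so it adds little. Nothing measured shows how chloro compares with fluoro in this series, so the expected step is kept modest: a 1.9-fold lower number from compound 2 to compound 4 (0.28 log units; within the scatter), in the lowering direction seen for compound 3. Compound 4 is therefore estimated at 130 nM, with a range from 60 nM to 300 nM.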

Compound 4, half-maximal inhibitory concentration: 440 nM
For compound 4 the middle estimate is 3.4-fold (0.53 log units) below the measured one; measured number above the stated range.
By their numbers in this assay, from the lowest: compounds 3, 1, 2 and 4 (each within the scatter of the next, the first and the last beyond it).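

In this assay the lowering seen on going from cyano to fluoro does not carry over to every halogen on this aromatic carbon, para to a large group: the direct comparison of the two halogens gives a 4.0-fold higher number from compound 3 to compound 4 (0.60 log units; beyond the scatter), which is beyond the scatter and separates chloro from fluoro at this position. Chloro in place of cyano gives a 1.8-fold higher number from compound 2 to compound 4 (0.25 log units; within the scatter), and the change from the 3-fluorophenyl gives a 2.0-fold higher number from compound 1 to compound 4 (0.30 log units; within the scatter); both lie within the scatter, so compound 4 cannot be ordered against compound 2 or compound 1, and only compound 3 is separated from it. Nothing available accounts for the difference between fluoro and chloro on this carbon.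

The compounds shown leave open where bromo, methyl, methoxy or an amine on this same carbon would fall relative to fluoro and chloro. They also leave open whether chloro and fluoro would separate in the same way at the position that carries the fluoro in compound 1.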